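This account rests on a few compounds, and the source may have more. Where it says the series, first, only, none or still open, it means among the compounds named here.

In a functional assay on HEK293 cells for agonist activity at 5-hydroxytryptamine receptor 1F (Homo sapiens), read by FLIPR, with a stated time of 60 min (on this read-out lower numbers stand for stronger inhibition and higher numbers for weaker inhibition), compound 2 `CN1CCC(=C(F)c2cccc(NC(=O)c3ccc(Cl)cn3)n2)CC1` gives 161 nM, the higher of the two numbers shown; its only neighbour is compound 1 `CN1CCC(=C(F)c2cccc(NC(=O)c3ccc(F)cn3)n2)CC1`, which gives 24.3 nM, and the step of a 6.6-fold higher number from compound 1 to compound 2 (0.82 log units; beyond the scatter) is the sole measured change so far. Compound 3 `CN1CCC(=C(F)c2cccc(NC(=O)c3ccc(Cl)cc3F)n2)CC1` differs from compound 2 by 4-chloro-2-fluorophenyl in place of 5-chloropyridin-2-yl on a carbonyl carbon. Among the measured compounds shown here, no measured step covers an exchange of the whole ring on the carbonyl carbon, so the step from compound 2 to compound 3 in this assay can only be expected to stay near the measured spread, with an estimated step of a 1.1-fold lower number from compound 2 to compound 3 (0.03 log units; within the scatter). Compound 3 is therefore estimated at 150 nM, within a range of 40 nM to 600 nM.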

Compound 3, half-maximal inhibitory concentration: 23.4 nM
For compound 3 the middle estimate is 6.4-fold (0.81 log units) above the measured one; measured number below the stated range.
By their numbers in this assay, from the lowest: compounds 3 and 1 (each within the scatter of the next); then compound 2.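

In this assay, 4-chloro-2-fluorophenyl in place of 5-chloropyridin-2-yl on the carbonyl carbon gives a 6.9-fold lower number from compound 2 to compound 3 (0.84 log units; beyond the scatter), so a chloro group does not by itself go with the high number of compound 2, and a ring of carbon only is accepted at this position. The other step, a 1.0-fold lower number from compound 1 to compound 3 (0.02 log units; within the scatter), puts the two rings level. No measurement given here accounts for these steps. From the compounds shown here alone, the change swaps the ring nitrogen and adds a fluoro group at once, and the share of each stays open. Also open, going by these compounds, is how a nitrile or a methoxy group in place of the chloro would read.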